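A few compounds are considered here, and "the series" means these few. Any claim that something is new, unique, unknown or untested is made for them only; others in the source may bear on it.

Measured in a functional assay on MCF7 cells (Homo sapiens) for antiproliferative activity, read by colorimetric assay and MTT assay, with a stated time of 48 h; a higher number here means a weaker inhibitor, a lower number a stronger inhibitor:
- compound 1 `O=C(NS(=O)(=O)c1ccc(F)cc1)c1ccncc1`: 13900 nM
- compound 2 `O=C(NS(=O)(=O)c1ccc(Br)cc1)c1ccncc1`: 8700 nM

Within the data shown here, compound 2 stands within the scatter of the only other measured compound: a 1.6-fold lower number from compound 1 to compound 2 (0.20 log units; within the scatter). Compound 3 `O=C(NS(=O)(=O)c1ccc(Br)cc1)c1ccccn1` is the next change, with pyridin-2-yl in place of pyridin-4-yl on a carbonyl carbon. Among the measured compounds shown here, the one measured step is bromo in place of fluoro on an aromatic carbon, so no measured step touches the pyridinyl group. No direction can be drawn from the data, and nothing beyond the scatter is expected in this assay. The expected change is a 1.1-fold higher number from compound 2 to compound 3 (0.06 log units; within the scatter). For compound 3 the estimated value is 10000 nM, with an expected range of 4000 nM to 25000 nM.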

Compound 3, half-maximal inhibitory concentration: 6800 nM
The estimate for compound 3 lay 1.5-fold (0.17 log units) above the measured number; measured number inside the range.
By their numbers in this assay, from the lowest: compounds 3, 2 and 1 (each within the scatter of the next, the first and the last beyond it).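

Among these compounds, on the carbonyl carbon, this is the first measured change to the pyridinyl group: in this assay pyridin-2-yl in place of pyridin-4-yl gives a 1.3-fold lower number from compound 2 to compound 3 (0.11 log units; within the scatter) and leaves the two compounds within the scatter of each other. This exchange of two groups with the same atoms therefore does not separate compound 2 and compound 3 in this assay. No supporting measurement bears on this result.

Still open, as far as these compounds go, is whether a phenyl, a piperidine or a carboxylic acid at this carbonyl carbon would move the number beyond the scatter. Also open, from the compounds shown here alone, is whether the bromo and fluoro comparison holds with pyridin-2-yl in place.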